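A Ring Methyl That Switches Off Activity in Mice

A few compounds are considered here, and "the series" means these few. Any claim that something is new, unique, unknown or untested is made for them only; others in the source may bear on it.

Compound 1, `CC(=O)N(C)C(C)C#CCn1ccnc1`, is tested in a functional assay on the whole organism for agonist activity, with Mus musculus as the target (a higher number here means that more compound is needed for the effect, a lower number that less compound is needed), where compound 1 gives 2 mg/kg. Compound 2, `CC(=O)N(C)C(C)C#CCn1cncc1C`, differs from compound 1 in one place: methyl in place of hydrogen on an aromatic carbon. In this assay compound 2 reaches only a limit of the assay, > 100 mg/kg. Taken as a step, this is an at least 50-fold higher number from compound 1 to compound 2 (1.69 log units; beyond the scatter). That step ends at the limit of > 100 mg/kg in this assay, at which 1 of the 3 values shown sits.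

Compound 3, `COC(=O)N(C)CC#CCn1ccnc1`, is built on a different core; how the two cores differ is not broken down here. In this assay compound 3 gives 2 mg/kg, which is level with compound 1 at the digits shown and within the scatter.

Compound 4, `COC(=O)N(C)CC#CCn1cncc1C`, has not yet been measured. From compound 3 to compound 4 the change is methyl in place of hydrogen on an aromatic carbon. The place of the change is described in the same words as for the change from compound 1 to compound 2, so it is the same change made on the core of compound 3. Going by the values given here, the only guide to what it may do is the measured step of an at least 50-fold higher number from compound 1 to compound 2 (1.69 log units; beyond the scatter). On that basis the expected step is a 50-fold higher number from compound 3 to compound 4 (1.70 log units; beyond the scatter). Compound 4 is therefore estimated to give 100 mg/kg in this assay, with the estimate spanning 25 mg/kg to 400 mg/kg, and there is a good chance that the assay will again report only a limit rather than a number.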

Compound 4, dose for half-maximal effect: 4.5 mg/kg
The estimate for compound 4 lay 22-fold (1.35 log units) above the measured number; measured number outside the range, below it.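

In this assay, methyl in place of hydrogen on an aromatic carbon has a much smaller effect on the core of compound 3 than on the core of compound 1, with a 2.3-fold higher number from compound 3 to compound 4 (0.35 log units; beyond the scatter), so the size of the step measured on one core does not carry over to the other: the same change on two cores in this assay, an at least 50-fold higher number (1.69 log units; beyond the scatter) from compound 1 to compound 2 and a 2.3-fold higher number (0.35 log units; beyond the scatter) from compound 3 to compound 4, at least 22-fold (1.34 log units) apart, beyond the scatter of two such steps

Both steps run in the same direction, towards more compound being needed for the effect, but two pairs are too few to establish a rule for the series, and they do not show which feature of the cores sets the size of the step. Compound 2 stands at a limit of the assay rather than at a number, so its step gives only a minimum and the true gap between the two steps remains unknown: the limit of > 100 mg/kg in this assay, at which 1 of the 4 values shown sits.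

The compounds shown leave open which part of the difference between the two cores matters, as no pair here separates one feature of those cores from another. On these data alone, it also remains open whether an ethyl group or a chlorine atom in the same place would shift the number on each core as the methyl does.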